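This account rests on a few compounds, and the source may have more. Where it says the series, first, only, none or still open, it means among the compounds named here.

Of the compounds shown here, two that share one core have been tested in a functional assay on ACHN cells (Homo sapiens); on this read-out lower numbers stand for stronger inhibition of growth and higher numbers for weaker inhibition of growth. Compound 1 `O=S(=O)(/C=C/c1ccc(F)cc1)Cc1ccc(Nc2ncnc3ccccc23)cc1` gives 10 nM in this assay. Going by the values given here, compound 2 `O=S(=O)(/C=C/c1ccc(Cl)cc1Cl)Cc1ccc(Nc2ncnc3ccccc23)cc1` gives 100 nM in this assay, which is the highest of the two numbers so far; its only neighbour is compound 1, and the step of a 10-fold higher number from compound 1 to compound 2 (1.00 log units; beyond the scatter) is the single measured comparison available. Compound 3 `O=S(=O)(/C=C/c1ccc(C(F)(F)F)cc1F)Cc1ccc(Nc2ncnc3ccccc23)cc1` has not yet been measured. It differs from compound 2 in one place: 2-fluoro-4-(trifluoromethyl)phenyl in place of 2,4-dichlorophenyl on a double-bonded chain carbon bound to a double-bonded chain carbon. Among the compounds with values here, the one measured step bears on this only loosely: it exchanged a ring bearing a single fluorine for one bearing two chlorines, and the number rose modestly. The ring that enters in compound 3 resembles the ring it replaces more closely than the ring of compound 1 does, so compound 3 is expected to land nearer to compound 2 than to compound 1. Compound 3 is therefore estimated to give 100 nM in this assay, with a likely range from 30 nM to 400 nM. The estimated step of no change at the digits printed from compound 2 to compound 3 (within the scatter) is expected to stay within the scatter.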

Compound 3, concentration for 50% growth inhibition: 100000 nM
For compound 3 the middle estimate is 1000-fold (3.00 log units) below the measured one, outside the stated range (above it).
By their numbers in this assay, from the lowest: compound 1; then compound 2; then compound 3.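

In this assay, the place on a double-bonded chain carbon bound to a double-bonded chain carbon proves far more sensitive than the first comparison suggested: the change from 2,4-dichlorophenyl to 2-fluoro-4-(trifluoromethyl)phenyl gives a 1000-fold higher number from compound 2 to compound 3 (3.00 log units; beyond the scatter) and this dwarfs the earlier 10-fold higher number from compound 1 to compound 2 (1.00 log units; beyond the scatter) in size. Against the 4-fluorophenyl ring the change is a 10000-fold higher number from compound 1 to compound 3 (4.00 log units; beyond the scatter) even though both rings carry fluorine and the leaving and entering groups alike have one six-membered aromatic ring, no hydrogen-bond donors or acceptors and no net charge, so these shared features do not protect growth inhibition, while the counted differences are 8 against 11 heavy atoms and chlorine against fluorine. No measurement available here accounts for this sharp loss of growth inhibition.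

The entering group differs from the earlier rings in more than one feature at once, so the share of the trifluoromethyl group and the share of the fluorine in this loss cannot be separated. Also open, going by these compounds, is how this place would respond to a ring carrying a methoxy group, an amine or a carboxylic acid.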